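Moving the chlorine on the benzyl group: compound 2 to compound 4

A few compounds are considered here, and "the series" means these few. Any claim that something is new, unique, unknown or untested is made for them only; others in the source may bear on it.

Working notes on the series. In an ADME assay on HEL cells (Homo sapiens) for cytotoxicity, with a stated time of 3 days (a lower number here means that less compound is tolerated, a higher number that more compound is tolerated), compound 1 `O=S1(=O)C=C(OCc2ccccc2)C(Cc2ccccc2)(Cc2ccccc2)O1` gives 200000 nM. Compound 3 `CC(C)C1(Cc2ccccc2)OS(=O)(=O)C=C1OCc1ccccc1` gives 200000 nM in this assay. Among the compounds with values here, the one measured step, no change at the digits printed from compound 1 to compound 3 (within the scatter), concerns a saturated ring carbon and not the chlorinated benzyl group. Compound 2 `CCC1(Cc2ccccc2)OS(=O)(=O)C=C1OCc1ccc(Cl)cc1` gives only a limit in this assay, > 200000 nM, which is not a number. Compound 2 therefore stands at the limit of > 200000 nM in this assay, at which 1 of the 3 values shown sits, the upper edge of what was tested. Compound 4 `CCC1(Cc2ccccc2)OS(=O)(=O)C=C1OCc1cccc(Cl)c1` remains to be measured. The change from compound 2 is 3-chlorophenyl in place of 4-chlorophenyl on a saturated chain carbon bound to an oxygen on an unsaturated carbon. Within the data shown here, no measured step touches the place of the chlorine, so the only guidance is that the single step measured stayed within the scatter; the expectation for this assay is therefore no step beyond the scatter, in either direction, with a good chance that a limit is reported again. Compound 4 is estimated at 200000 nM, within 100000 nM to 400000 nM. The expected step is a number no higher from compound 2 to compound 4 (the limit leaves the size open).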

Compound 4, half-maximal cytotoxic concentration: 50000 nM
Beside the measured number, compound 4's estimate is 4.0-fold (0.60 log units) above it; the measured number lies below the stated range.
By their numbers in this assay, from the lowest: compound 4; then compounds 1 and 3 (each within the scatter of the next).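

In this assay, the place of the chlorine on the benzyl group matters: 3-chlorophenyl in place of 4-chlorophenyl, with the same atoms joined differently, gives an at least 4.0-fold lower number from compound 2 to compound 4 (0.60 log units; beyond the scatter). Within the data shown here, the one earlier step, no change at the digits printed from compound 1 to compound 3 (within the scatter), lay on a saturated ring carbon and gave no sign that any change could move the number beyond the scatter. The full size of the new step cannot be read, because compound 2 is held only by a limit and not by a number: the limit of > 200000 nM in this assay, at which 1 of the 4 values shown sits.

The compounds shown leave open whether a fluorine or a methoxy group in the place of this chlorine would lower the number as well. They also leave open whether the same move gives a step of like size on the benzyl groups of compound 1 or compound 3.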